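The source may report more compounds than this note shows. Statements on the series, on what has been measured and on what is new or still open speak of the compounds shown alone.

Working notes on the series. In an ADME assay on S9 fraction from liver (Homo sapiens) for metabolic stability, with a stated time of 1 h (a lower number here means that less of the compound is left, a higher number that more of the compound is left), compound 1 `N#Cc1cnc(NCc2cnccc2C(F)(F)F)cc1N[C@H]1CC[C@@H](O)CC1` gives 33%, the lowest of the three numbers recorded so far. Compound 2 `N#Cc1cnc(NCc2cnccc2C(F)(F)F)cc1NC1CCOCC1` gives 91% in this assay, and compound 3 `N#Cc1cnc(NCc2ccccc2C(F)(F)F)cc1N[C@H]1C[C@@H](C(N)=O)C1` gives 86%. Among the compounds with values here, the only single-point step among the measured compounds, a number 58 percentage points higher from compound 1 to compound 2 (beyond the scatter), is large and well beyond the scatter. Compound 4 `N#Cc1cnc(NCc2cnccc2C(F)(F)F)cc1N[C@H]1CC[C@@H](C(N)=O)CC1` is the next step out from compound 1: carbamoyl in place of hydroxy on a saturated ring carbon. Within the data shown here, compound 3, which also carries a carbamoyl group on its saturated ring, sits well above compound 1 in this assay, though it differs at more than one place and no single step connects the two. A rise beyond the scatter is therefore expected in this assay, of about a number 42 percentage points higher from compound 1 to compound 4 (beyond the scatter). For compound 4 the expected value is 75%, with a range from 50% to 92%.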

Compound 4, percent of the compound remaining: 90%
For compound 4 the middle estimate is 15 percentage points below the measured one; measured number inside the range.
By their numbers in this assay, from the lowest: compound 1; then compounds 3, 4 and 2 (each within the scatter of the next).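

In this assay, carbamoyl in place of hydroxy on the saturated ring carbon gives a number 57 percentage points higher from compound 1 to compound 4 (beyond the scatter) and so the low number of compound 1 does not go with the six-membered non-aromatic ring of carbon only as such. With a number 1 percentage points lower from compound 2 to compound 4 (within the scatter) as well, 4-carbamoylcyclohexyl and oxan-4-yl cannot be told apart in this read-out. Nothing available bears on why the number rises at this position.

The compounds shown leave open how a carboxylic acid or an amine on the same ring carbon would read. As far as these compounds go, whether a methyl ether in place of hydroxy would give a similar rise also remains open.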